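The compounds below may be only part of what the source reports. "The series", "measured", "known", "first", "only" and "open" are said of these compounds alone.

Three amides built on one shared core have been measured in a functional assay on A-375 cells (Homo sapiens) for antiproliferative activity, read by MTT assay, with a stated time of 24 h, tested at 0.05 ug/mL; a higher number here means a stronger effect of the compound at the concentration tested, a lower number a weaker effect. Compound 1 `Cc1c(C(=O)Nc2c(F)cc(-c3cccc(F)c3)cc2F)nc2ccc(C(F)(F)F)cc2c1O` gives 3.47%. Compound 2 `CCc1ccc2nc(C(=O)Nc3c(F)cc(-c4cccc(F)c4)cc3F)c(C)c(C(=O)O)c2c1` gives 0.95% in this assay. Compound 3 `Cc1c(C(=O)Nc2c(F)cc(-c3cccc(F)c3)cc2F)nc2ccc(F)cc2c1C(=O)O` gives 0.37% in this assay, the lowest of the three numbers, although its gap to compound 2 and its gap to compound 1 both lie within the scatter, so no order among the three can be read from them. Within the data shown here, the only single-point step among the measured compounds is a number 0.6 percentage points lower from compound 2 to compound 3 (within the scatter). Compound 4 `Cc1c(C(=O)Nc2c(F)cc(-c3cccc(F)c3)cc2F)nc2ccc(C(F)(F)F)cc2c1C(=O)O` differs from compound 3 by trifluoromethyl in place of fluoro on an aromatic carbon. Among the measured compounds shown here, the step from compound 2 to compound 3 is the one measured step that bears on this change, and it stayed within the scatter. Compound 1 also carries a trifluoromethyl, yet it differs from compound 3 in a second place as well, so only its value can be set beside the others: compound 1 shows 3.47%, again close to compound 3. On this basis the step is expected to remain within the scatter, a number 1.1 percentage points higher from compound 3 to compound 4 (within the scatter). Compound 4 is therefore estimated at 1.5% in this assay, with a range from 0% to 8%.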

Compound 4, a percentage reported as inhibition, at one concentration (the size of the read-out at that concentration, not a potency): 1.04%
Estimate against measurement, compound 4: 0.5 percentage points above, and the stated range covers the measured number.
By their numbers in this assay, from the lowest: compounds 3, 2, 4 and 1 (each within the scatter of the next).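

In this assay trifluoromethyl in place of fluoro on this aromatic carbon gives a number 0.7 percentage points higher from compound 3 to compound 4 (within the scatter) and trifluoromethyl in place of ethyl gives a number 0.1 percentage points higher from compound 2 to compound 4 (within the scatter) so fluoro, ethyl and trifluoromethyl at this position cannot be told apart by this read-out. With trifluoromethyl held constant, carboxy in place of hydroxy on another aromatic carbon gives a number 2.4 percentage points lower from compound 1 to compound 4 (within the scatter) and so does not separate those two groups either. Nothing available explains any of these steps.

The compounds shown leave open whether an amine or a methoxy group on the trifluoromethyl-bearing carbon, or a methyl ester in place of the carboxy, would give a step beyond the scatter. With a single tested concentration, they also leave the potency of all four compounds open.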